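A few compounds are considered here, and "the series" means these few. Any claim that something is new, unique, unknown or untested is made for them only; others in the source may bear on it.

Measured so far, in a functional assay (B cells) with Mus musculus as the target; a lower number here means that less compound is needed, a higher number that more compound is needed for the effect:
compound 1 `Nc1nc(O)c2c(n1)n(C1OC(CO)[C@@H](O)[C@H]1O)c(=O)n2CC(O)CSc1ccccc1` gives 142 uM
compound 2 `C=CCn1c(=O)n(CCC(CCOCc2ccccc2)CCOCc2ccccc2)c2nc(N)nc(O)c21` gives 7 uM
compound 3 `C=CCn1c(=O)n(C2OC(CO[Si](c3ccccc3)(c3ccccc3)C(C)(C)C)[C@@H](O)[C@H]2O)c2nc(N)nc(O)c21` gives 18 uM

Compound 1 stands highest of the three; compound 3 is nearest, compound 2 furthest, and both gaps lie beyond the scatter. Compound 4 `COc1ccc(Cn2c(=O)n(C3OC(CO)[C@@H](O)[C@H]3O)c3nc(N)nc(O)c32)cc1` is not yet measured. It differs from compound 1 in one place: 4-methoxyphenyl in place of 1-hydroxy-2-(phenylsulfanyl)ethyl on a saturated chain carbon bound to an aromatic nitrogen. Both keep the shared core and the same sugar. For the measured compounds named here, no step between measured compounds matches this change, so the expectation rests on where compound 1 stands. With compound 1 at the top of the set, a moderate step downward is expected, a 3.2-fold lower number from compound 1 to compound 4 (0.50 log units; beyond the scatter), though a step within the scatter cannot be ruled out. Compound 4 is estimated at 45 uM, range 10 uM to 200 uM.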

Compound 4, concentration for half-maximal effect: 135 uM
Estimate against measurement, compound 4: 3.0-fold (0.48 log units) below; low and high end bracket the measured number.
By their numbers in this assay, from the lowest: compound 2; then compound 3; then compounds 4 and 1 (each within the scatter of the next).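

In this assay, for the compounds shown here, the exchange of 1-hydroxy-2-(phenylsulfanyl)ethyl for 4-methoxyphenyl on a saturated chain carbon bound to an aromatic nitrogen gives a 1.1-fold lower number from compound 1 to compound 4 (0.02 log units; within the scatter) and is the only one-place comparison. With the shared core and the same sugar kept, this position accepts either group, and the loss of the hydroxyl and the sulfur leaves nothing to separate the two compounds. As far as these compounds go, whether an amine or a carboxylic acid at this position, on the same sugar, would separate from them stays open. No evidence on hand speaks to why the two groups read alike.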